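A few compounds are considered here, and "the series" means these few. Any claim that something is new, unique, unknown or untested is made for them only; others in the source may bear on it.

Compound 1 `c1ccc(Cn2cc(-c3ccccc3)c3c2CCNC3)cc1`: 220 nM in an assay on HEK293 cells for displacement of a labelled ligand from 5-hydroxytryptamine receptor 7 (Rattus norvegicus), with a stated time of 60 min; a higher number here means a weaker inhibitor, a lower number a stronger inhibitor
Compound 2 `FC(F)(F)Oc1ccc(-c2cn(Cc3ccccc3)c3c2CNCC3)cc1`: 10000 nM in this assay
Compound 3 `FC(F)(F)c1ccc(-c2cn(Cc3ccccc3)c3c2CNCC3)cc1`: 167 nM in this assay

Among these three numbers compound 1 stands second highest. Its nearest neighbour is compound 3, reached by a 1.3-fold lower number from compound 1 to compound 3 (0.12 log units; within the scatter), a step that stays within the scatter. Its furthest neighbour is compound 2, reached by a 45-fold higher number from compound 1 to compound 2 (1.66 log units; beyond the scatter), a step far beyond the scatter. Between the two substituted compounds lies a 60-fold lower number from compound 2 to compound 3 (1.78 log units; beyond the scatter).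

Compound 4 `Fc1cccc(-c2cn(Cc3ccccc3)c3c2CNCC3)c1` differs from compound 1 in one place: fluoro in place of hydrogen on an aromatic carbon. The measured steps that bear on this change are the two substitutions on the same ring of compound 1. Putting trifluoromethyl there left the number essentially where it was, while putting trifluoromethoxy there raised it strongly. For the measured compounds named here, neither is fluoro, and no step with fluoro on this ring has been measured, so the guidance is indirect. Fluoro is the smaller group of the three. The expectation is therefore a step in this assay that stays within the scatter, or at most a modest rise.

For compound 4 the estimated value in this assay is 260 nM, with a range from 80 nM to 900 nM, which means an expected step of a 1.2-fold higher number from compound 1 to compound 4 (0.07 log units; within the scatter).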

Compound 4, inhibition constant: 2730 nM
Beside the measured number, compound 4's estimate is 11-fold (1.02 log units) below it, outside the stated range (above it).
By their numbers in this assay, from the lowest: compounds 3 and 1 (each within the scatter of the next); then compound 4; then compound 2.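

A single fluorine atom, the smallest group on this ring so far, gives a 12-fold higher number from compound 1 to compound 4 (1.09 log units; beyond the scatter) in this assay and so counts as a large step, which shows that the phenyl ring of compound 1 is sensitive even to a change of one heavy atom. The size of the entering group does not set the outcome among the compounds shown, since trifluoromethyl gives only a 1.3-fold lower number from compound 1 to compound 3 (0.12 log units; within the scatter) and stays within the scatter, whereas fluoro, with far fewer atoms, and trifluoromethoxy, with more, both raise the number well beyond it, the latter by a 45-fold higher number from compound 1 to compound 2 (1.66 log units; beyond the scatter) and so further still. Nothing measured here explains why this one fluorine atom has so large an effect.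

The compounds shown leave open whether the large step belongs to fluoro itself or to the place it occupies, meta to a large group, so a chloro or a methoxy group in that same place would be informative. Equally open, from the compounds shown here alone, is what fluoro would do elsewhere on this ring, for example in the place held by trifluoromethyl in compound 3, and whether a second fluoro would add to the step.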